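The source may report more compounds than this note shows. Statements on the series, on what has been measured and on what is new or still open speak of the compounds shown alone.

Measured so far:
compound 1 `CCOC(=O)c1cccc(-c2ccc(OCC)cc2)c1`: 87%
compound 2 `CCOc1ccc(-c2cccc(C)c2)cc1`: 54%
compound 3 `CCCCCCOC(=O)c1cccc(-c2ccc(OCC)cc2)c1`: 48%

These numbers come from an assay on COS-7 cells for inhibition of patatin-like phospholipase domain-containing protein 2 (Mus musculus), tested at 200 uM; a higher number here means more inhibition at the concentration tested (going by the name of the read-out), a lower number less inhibition. Compound 3 gives the lowest of the three numbers; its gap to compound 2 lies within the scatter, while compound 1 stands clearly higher, as the step of a number 39 percentage points lower from compound 1 to compound 3 (beyond the scatter) shows. Compound 4 `CCOc1ccc(-c2cccc(C(=O)NC)c2)cc1` is not yet measured. It differs from compound 3 in one place: methylamino in place of hexyloxy on a carbonyl carbon. Among the compounds with values here, no measured step makes this exact change. The step of a number 39 percentage points lower from compound 1 to compound 3 (beyond the scatter) shows that a longer chain at the carbonyl lowered inhibition, and the step of a number 33 percentage points lower from compound 1 to compound 2 (beyond the scatter) shows that losing the carbonyl group altogether also lowered it. Compound 4 keeps the carbonyl and carries a shorter group, so a rise is expected, a number 17 percentage points higher from compound 3 to compound 4 (beyond the scatter), though its size is uncertain. Compound 4 is expected to give 65%, within 35% to 90%.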

Compound 4, a percentage reported as inhibition, at one concentration (the size of the read-out at that concentration, not a potency): 40%
For compound 4 the middle estimate is 25 percentage points above the measured one; the measured number falls inside the stated range.
By their numbers in this assay, from the lowest: compounds 4, 3 and 2 (each within the scatter of the next, the first and the last beyond it); then compound 1.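

Putting methylamino in place of hexyloxy on the carbonyl carbon (a number 8 percentage points lower from compound 3 to compound 4 (within the scatter)) shows that a smaller group there does not by itself bring back the inhibition seen with compound 1. The amide also sits clearly apart from the methyl compound (a number 14 percentage points lower from compound 2 to compound 4 (beyond the scatter)) and from the ethyl ester (a number 47 percentage points lower from compound 1 to compound 4 (beyond the scatter)), so keeping the carbonyl is not enough, and what is attached to it matters. No evidence here explains these differences.

On these data alone, whether a carboxylic acid, a methyl ester or a propyl ester at this carbonyl carbon would match compound 1 or compound 4 remains open.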